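Thiophen-2-yl in Place of Ethoxycarbonyl in a Small Series

This account rests on a few compounds, and the source may have more. Where it says the series, first, only, none or still open, it means among the compounds named here.

Compound 1 `CCOC(=O)c1cn(C[C@H]2O[C@@H](n3ccc(=O)[nH]c3=O)[C@H](SCC)[C@@H]2SCC)nn1` gives in a functional assay on HepG2 cells (Homo sapiens) for cytotoxicity, read by MTT assay, with a stated time of 72 h (a lower number here means that less compound is needed, a higher number that more compound is needed for the effect), a value that is only a limit of the assay, >= 100000 nM.
Compound 2 `CCS[C@@H]1[C@H](SCC)[C@@H](Cn2cc(-c3cccs3)nn2)O[C@H]1n1ccc(=O)[nH]c1=O` gives in this assay 91800 nM.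
Compound 3 `CCOC(=O)c1cn(C[C@H]2O[C@@H](n3cc(C)c(=O)[nH]c3=O)[C@H](SCC)[C@@H]2SCC)nn1` gives in this assay only a limit of the assay, >= 100000 nM.

Compound 2 differs from compound 1 by thiophen-2-yl in place of ethoxycarbonyl on an aromatic carbon, and this gave an at least 1.0-fold lower number from compound 1 to compound 2 (0.03 log units; that floor lies within the scatter). Compound 3 differs from compound 1 by methyl in place of hydrogen on an aromatic carbon, a step that the two limits leave unreadable from compound 1 to compound 3. Compound 4 `CCS[C@@H]1[C@H](SCC)[C@@H](Cn2cc(-c3cccs3)nn2)O[C@H]1n1cc(C)c(=O)[nH]c1=O` has not been measured; it differs from compound 3 by thiophen-2-yl in place of ethoxycarbonyl on an aromatic carbon, the same change as between compound 1 and compound 2. For compound 4 a step of an at least 1.0-fold lower number from compound 3 to compound 4 (0.02 log units; that floor lies within the scatter) is expected, resting on an at least 1.0-fold lower number from compound 1 to compound 2 (0.03 log units; that floor lies within the scatter) and on (the limit of >= 100000 nM in this assay, at which 2 of the 3 values shown sit), which leaves the size of that earlier step unreadable. Compound 4 is therefore estimated at 95000 nM, between 45000 nM and 200000 nM.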

Compound 4, half-maximal effective concentration: >= 100000 nM
Compound 4 ended at the assay's limit (the forecaster's own chance of this, stated with the estimate: 50%); middle value at least 1.0-fold (0.02 log units) from the limit.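

In this assay compound 4 gives >= 100000 nM, which is a limit of the assay and not a number. The steps between compound 1 and compound 3 and between compound 3 and compound 4 cannot be read, so carrying thiophen-2-yl in place of ethoxycarbonyl onto the methyl-bearing core is neither confirmed nor ruled out, because the values crowd at one limit: the limit of >= 100000 nM in this assay, at which 3 of the 4 values shown sit. Methyl in place of hydrogen gives an at least 1.0-fold higher number from compound 2 to compound 4 (0.03 log units; that floor lies within the scatter), and this floor leaves the true size of the step unknown.

Left open is whether an amine, a carboxylic acid or a longer chain at this place on the ring would give a readable value in this assay.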